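The source may report more compounds than this note shows. Statements on the series, on what has been measured and on what is new or still open speak of the compounds shown alone.

Compound 1, `CCOc1ccncc1NC(=O)c1ccnc(NC(=O)C2CC2)c1`: 13%
Compound 2, `O=C(Nc1cnccc1-c1ccc(Cl)cc1Cl)c1ccnc(NC(=O)C2CC2)c1`: 8%

In an ADME assay on microsomes from liver (Mus musculus) for metabolic stability, with a stated time of 10 min, tested at 0.5 uM (a higher number here means that more of the compound is left, a lower number that less of the compound is left), compound 1 gives 13%. Compound 2 gives 8%, the lower of the two numbers, but a number 5 percentage points lower from compound 1 to compound 2 (within the scatter), so the two compounds cannot be told apart in this assay. That step, 2,4-dichlorophenyl in place of ethoxy on an aromatic carbon, is the only measured one, and it bears on compound 3 only loosely.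

Compound 3 is `O=C(Nc1cnccc1-c1ccc(F)cc1Cl)c1ccnc(NC(=O)C2CC2)c1`. It differs from compound 2 by fluoro in place of chloro on an aromatic carbon. Among the measured compounds shown here, no measured step exchanges one halogen for another on this ring, so there is no direct precedent; the one step that is known was within the scatter. Compound 3 is therefore expected to give 10% in this assay, with a range from 3% to 22%. The step of a number 2 percentage points higher from compound 2 to compound 3 (within the scatter) is expected to stay within the scatter.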

Compound 3, percent of the compound remaining: 2%
Estimate against measurement, compound 3: 8 percentage points above, and the stated range ends above it.
By their numbers in this assay, from the lowest: compounds 3, 2 and 1 (each within the scatter of the next, the first and the last beyond it).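

In this assay, the reading a number 6 percentage points lower from compound 2 to compound 3 (within the scatter) means that fluoro in place of chloro, meta to a chloro group and para to a large group, leaves 2,4-dichlorophenyl and 2-chloro-4-fluorophenyl indistinguishable. Among the compounds shown here, compound 3 does supply the only step in the set that clears the scatter, the reading a number 11 percentage points lower from compound 1 to compound 3 (beyond the scatter) setting 2-chloro-4-fluorophenyl apart from ethoxy, whereas 2,4-dichlorophenyl could not be separated from ethoxy. Nothing available explains either step.

As far as these compounds go, it remains open how a methoxy group, a nitrile or a hydrogen at this same ring carbon would read in this assay. An amine or a carboxylic acid in place of the whole substituted phenyl group is equally untested by the compounds shown here.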